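Hydroxy on the chain and tolerated concentration

This account rests on a few compounds, and the source may have more. Where it says the series, first, only, none or still open, it means among the compounds named here.

Compound 1 `C(C[C@@H]1COCCO1)C[C@@H]1COCCO1` and compound 2 `OC(C[C@@H]1COCCO1)C[C@@H]1COCCO1` differ in a single place. In an ADME assay on BHK cells (Mesocricetus auratus) for cytotoxicity, read by XTT assay (a lower number here means that less compound is tolerated, a higher number that more compound is tolerated), compound 1 gives > 1000000 nM, which is a limit of the assay rather than a number. In this assay compound 2 gives > 1000000 nM, likewise a limit. The change between them is hydroxy in place of hydrogen on a saturated chain carbon bound to two saturated chain carbons, and the step it made is a step that the two limits leave unreadable from compound 1 to compound 2.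

Compound 3 `C(CC[C@@H]1COCCO1)C[C@@H]1COCCO1` has a core whose difference from the core of compound 1 is not broken down here. In this assay compound 3 gives > 1000000 nM, again a limit. Compound 4 `OC(CC[C@@H]1COCCO1)C[C@@H]1COCCO1` has not yet been measured; it differs from compound 3 by hydroxy in place of hydrogen on a saturated chain carbon bound to two saturated chain carbons, the same change that leads from compound 1 to compound 2.

Within the data shown here, the step of a number no higher from compound 3 to compound 4 (the limit leaves the size open) is expected to be small, because every value so far sits at the limit of > 1000000 nM in this assay, at which 3 of the 3 values shown sit, and the same change from compound 1 to compound 2 gave no readable movement. Compound 4 is therefore estimated to give about 1000000 nM in this assay, most likely again reported only as a limit, with an expected range from 300000 nM to 3000000 nM.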

Compound 4, half-maximal cytotoxic concentration: > 1000000 nM
Compound 4 was reported as a limit; the forecaster's own chance of this, stated with the estimate: 85%; the middle value lies on the limit itself.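

In this assay compound 4 gives > 1000000 nM, which is a limit of the assay. Compound 3 is also reported only as a limit, so no step can be read between compound 3 and compound 4. The compounds shown leave open whether hydroxy on the chain changes the tolerated concentration at all, because all the values share one limit: the limit of > 1000000 nM in this assay, at which 4 of the 4 values shown sit.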